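Ring size at the amine end of the propoxy chain

This account rests on a few compounds, and the source may have more. Where it says the series, first, only, none or still open, it means among the compounds named here.

Compound 2 `COc1cc2c(Oc3ccc(NC(=O)c4cc(-c5ccccc5)ccn4)cc3F)ccnc2cc1OCCCN1CCCC1` gives 120 nM in a functional assay on HT-29 cells (Homo sapiens) for cytotoxicity, read by MTT assay, with a stated time of 72 h; on this read-out lower numbers stand for stronger inhibition and higher numbers for weaker inhibition; its analogue compound 3 `COc1cc2c(Oc3ccc(NC(=O)c4cc(-c5ccc(F)cc5)ccn4)cc3F)ccnc2cc1OCCCN1CCCC1` gives 430 nM, and compound 1 `COc1cc2c(Oc3ccc(NC(=O)c4cc(-c5ccc(F)cc5)ccn4)cc3F)ccnc2cc1OCCCN1CCCCC1` gives 1370 nM. The step of a 3.6-fold higher number from compound 2 to compound 3 (0.55 log units; beyond the scatter) comes from hydrogen in place of fluoro on an aromatic carbon read in reverse. The step of a 3.2-fold higher number from compound 3 to compound 1 (0.50 log units; beyond the scatter) comes from the change (piperidin-1-yl in place of pyrrolidin-1-yl on a saturated chain carbon, three bonds along the chain from an oxygen on an aromatic ring). Compound 4 `COc1cc2c(Oc3ccc(NC(=O)c4cc(-c5ccccc5)ccn4)cc3F)ccnc2cc1OCCCN1CCCCC1` is not yet measured; it carries the same change, (piperidin-1-yl in place of pyrrolidin-1-yl on a saturated chain carbon, three bonds along the chain from an oxygen on an aromatic ring), and the two cores differ only in the way described under (hydrogen in place of fluoro on an aromatic carbon). The place is identical in both pairs, so this is the same change. Among the measured compounds shown here, a step of about the size seen before is expected, a 3.2-fold higher number from compound 2 to compound 4 (0.50 log units; beyond the scatter), because the one measured instance, a 3.2-fold higher number from compound 3 to compound 1 (0.50 log units; beyond the scatter), is modest but beyond the scatter. Compound 4 is therefore estimated at 380 nM, with a range from 150 nM to 1000 nM.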

Compound 4, half-maximal inhibitory concentration: 270 nM
Beside the measured number, compound 4's estimate is 1.4-fold (0.15 log units) above it, within the range that was stated.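

In this assay, piperidin-1-yl in place of pyrrolidin-1-yl gives a 2.3-fold higher number from compound 2 to compound 4 (0.35 log units; beyond the scatter), and the step carries from the core of compound 3 to the core of compound 2 without a difference beyond the scatter: the same change on two cores in this assay, a 3.2-fold higher number (0.50 log units; beyond the scatter) from compound 3 to compound 1 and a 2.3-fold higher number (0.35 log units; beyond the scatter) from compound 2 to compound 4, 1.4-fold (0.15 log units) apart, within the scatter of two such steps
Hydrogen in place of fluoro gives a 5.1-fold lower number from compound 1 to compound 4 (0.71 log units; beyond the scatter), and this step likewise holds with either amine ring: the same change on two cores in this assay, a 3.6-fold higher number (0.55 log units; beyond the scatter) from compound 2 to compound 3 and a 5.1-fold higher number (0.71 log units; beyond the scatter) from compound 4 to compound 1, 1.4-fold (0.15 log units) apart, within the scatter of two such steps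
These four compounds show that the two changes transfer within this small set, but they do not show that either change would transfer to other cores or give a cause for either step.

Going by these compounds, a morpholine ring or a dimethylamino group at the end of the propyl chain remains open. So do a longer chain and a chloro group in place of the fluoro.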